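A few compounds are considered here, and "the series" means these few. Any claim that something is new, unique, unknown or untested is made for them only; others in the source may bear on it.

Measured so far:
Compound 1, `CCCCc1ccc(-c2cc(-c3cn([C@H]4C[C@H](OC(C)=O)[C@@H](COC(C)=O)O4)c(=O)[nH]c3=O)on2)cc1`: 3000 nM
Compound 2, `CCc1ccc(-c2cc(-c3cn([C@H]4C[C@H](OC(C)=O)[C@@H](COC(C)=O)O4)c(=O)[nH]c3=O)on2)cc1`: 3000 nM

In an ADME assay on HeLa cells (Homo sapiens) for cytotoxicity (a higher number here means that more compound is tolerated, a lower number that less compound is tolerated), compound 1 gives 3000 nM and compound 2 gives 3000 nM; the step of no change at the digits printed from compound 1 to compound 2 (within the scatter) leaves compound 2 level with compound 1 at the digits shown. Compound 3, `CC(=O)OC[C@H]1O[C@@H](n2cc(-c3cc(-c4ccc(C(C)(C)C)cc4)no3)c(=O)[nH]c2=O)C[C@@H]1OC(C)=O`, is the next member of the series and has not yet been measured in this assay. The change tert-butyl in place of ethyl on an aromatic carbon sits at the same position that was varied between compound 1 and compound 2. Within the data shown here, only that one step bears on the change, and it moved nothing beyond the scatter, so for compound 3 a step of about no change at the digits printed from compound 2 to compound 3 (within the scatter) in this assay is expected, without a clear direction. Compound 3 is therefore estimated at 3000 nM, with a range from 1500 nM to 6000 nM.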

Compound 3, half-maximal cytotoxic concentration: 3000 nM
Estimate against measurement, compound 3: no gap at the digits printed; low and high end bracket the measured number.
By their numbers in this assay, from the lowest: compounds 1, 2 and 3 (each within the scatter of the next).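

In this assay, tert-butyl in place of ethyl gives no change at the digits printed from compound 2 to compound 3 (within the scatter), and tert-butyl in place of butyl gives no change at the digits printed from compound 1 to compound 3 (within the scatter). The earlier comparison covered only the two unbranched chains, ethyl and butyl, so these steps add a branched group at the same place on the aromatic ring, and across these three compounds neither chain length nor branching separates the values. Nothing measured accounts for this flat reading.

As far as these compounds go, all three compounds carry a plain alkyl group here, so it remains open whether an amine, a carboxylic acid or a much longer chain at this position would shift the tolerated concentration. The compounds also leave open what free hydroxyl groups in place of the acetate esters on the shared core would do.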